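This account rests on a few compounds, and the source may have more. Where it says the series, first, only, none or still open, it means among the compounds named here.

Measured compounds and their lipophilicity readings:
compound 1, `CC[C@H](Nc1c(C#N)c(-c2ccc(Br)cc2)nc2cnccc12)C(N)=O`: 2.3
compound 2, `CC[C@@H](Nc1c(C#N)c(-c2ccc(-c3cccc(Cl)c3OC)cc2)nc2cnccc12)C(N)=O`: 3.1
compound 3, `CC[C@@H](Nc1c(C#N)c(-c2ccc(-c3cccc(Cl)c3F)cc2)nc2cnccc12)C(=O)O`: 2.2

In a physicochemical assay for lipophilicity, read by HPLC, at pH 7.5 (on this read-out higher numbers stand for higher lipophilicity and lower numbers for lower lipophilicity), compound 2 gives 3.1, the highest of the three numbers. The nearest value is that of compound 1, which gives 2.3, lower by a margin beyond the scatter; the furthest is that of compound 3, which gives 2.2, lower still and also beyond the scatter. Within the data shown here, no pair of these measured compounds differs in only one place, so no measured single step is available to lean on.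

Compound 4 is `CCOc1ccccc1-c1ccc(-c2nc3cnccc3c(N[C@H](CC)C(N)=O)c2C#N)cc1` and has not yet been measured in this assay. It is built from compound 2 by one change: 2-ethoxyphenyl in place of 3-chloro-2-methoxyphenyl on an aromatic carbon. Both the leaving group and the entering group sit para to a large group on the same aromatic carbon.

Among the measured compounds shown here, with no measured step of this kind to guide the number, the expectation rests on the value of compound 2 alone. The step expected from compound 2 to compound 4 is small, a number 0.20 log units lower from compound 2 to compound 4 (within the scatter), a slight move downward that would stay within the usual scatter. Compound 4 is therefore estimated at 2.9 in this assay, with a likely range from 2.5 to 3.3.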

Compound 4, distribution coefficient: 3
Beside the measured number, compound 4's estimate is 0.10 log units below it, within the range that was stated.
By their numbers in this assay, from the lowest: compounds 3 and 1 (each within the scatter of the next); then compounds 4 and 2 (each within the scatter of the next).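

In this assay, among these compounds, putting 2-ethoxyphenyl in place of 3-chloro-2-methoxyphenyl, on the aromatic carbon para to a large group, gives a number 0.10 log units lower from compound 2 to compound 4 (within the scatter), and this is the first step that can be read between two compounds differing in one place. The swap removes the chlorine and replaces the methoxy group with an ethoxy group, yet the read-out cannot tell compound 2 and compound 4 apart, so at this position the two groups are interchangeable as far as this measurement goes. Nothing measured here accounts for how close the two compounds lie.

Since the chlorine and the ethoxy group change together, this single step cannot show what either change does alone; a plain 2-methoxyphenyl group would be needed to separate them. On these data alone, it also remains open whether the same closeness would hold for a phenyl ring carrying an amine or a longer chain such as butoxy, since both groups compared here are aromatic ethers of similar size.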